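Methyl on the chain carbon: compound 3 to compound 4

The compounds below may be only part of what the source reports. "The series", "measured", "known", "first", "only" and "open" are said of these compounds alone.

Measured so far:
Compound 1 `N=c1c(C(N)=O)cc(Cl)cn1Cc1ccccc1` gives 30 nM in an assay on CHO-K1 cells for displacement of a labelled ligand from Alpha-1D adrenergic receptor (Homo sapiens), read by scintillation counting, with a stated time of 60 min; a higher number here means a weaker inhibitor, a lower number a stronger inhibitor.
Compound 2 `CN(C)C(=O)c1cc(Cl)cn(Cc2ccccc2)c1=N` reaches only the assay limit > 940 nM in this assay, a limit and not a number.
Compound 3 `CS(=O)(=O)c1cccc(Cn2cc(Cl)cc(C(N)=O)c2=N)c1` gives 52 nM in this assay.

Compound 3 holds the highest of the two numbers; its nearest neighbour is compound 1, and the step of a 1.7-fold higher number from compound 1 to compound 3 (0.24 log units; within the scatter) lies within the scatter. The other measured step, an at least 31-fold higher number from compound 1 to compound 2 (1.49 log units; beyond the scatter), is large and ends at the limit (the limit of > 940 nM in this assay, at which 1 of the 3 values shown sits).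

Compound 4 `CC(c1cccc(S(C)(=O)=O)c1)n1cc(Cl)cc(C(N)=O)c1=N` differs from compound 3 by methyl in place of hydrogen on a saturated chain carbon bound to an aromatic carbon and an aromatic nitrogen. Neither measured step touches this chain carbon: the large step concerns the carbonyl substituent, the small one the aromatic ring. Going by the values given here, with no direct precedent, a small step is expected, and compound 4 is estimated at 80 nM (range 25 nM to 260 nM). The expected step of a 1.5-fold higher number from compound 3 to compound 4 (0.19 log units; within the scatter) is judged likely to stay near the scatter, with the wider range reflecting the absence of any measured change at this position.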

Compound 4, inhibition constant: 15 nM
For compound 4 the middle estimate is 5.3-fold (0.73 log units) above the measured one; the measured number lies below the stated range.
By their numbers in this assay, from the lowest: compounds 4, 1 and 3 (each within the scatter of the next, the first and the last beyond it). At a limit, above all of these: compound 2.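

The saturated chain carbon bound to an aromatic carbon and an aromatic nitrogen accepts a substituent in this assay: methyl in place of hydrogen there gives a 3.5-fold lower number from compound 3 to compound 4 (0.54 log units; beyond the scatter). This is the only step shown that lowers the number beyond the scatter, so this chain carbon responds to a change of a single heavy atom, whereas methylsulfonyl on the aromatic carbon gave a step within the scatter. The compounds shown offer no measured basis for explaining this step.

On these data alone, it remains open whether an ethyl group or a longer chain on this carbon would lower the number further, or whether an amine there would reverse the step. Also open, as far as these compounds go, is whether methyl at this carbon gives a similar step on the core of compound 1, without the methylsulfonyl group.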